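From Fluoro to Iodo: Expectations for Compound 4

A few compounds are considered here, and "the series" means these few. Any claim that something is new, unique, unknown or untested is made for them only; others in the source may bear on it.

Compound 1 `CC(C)c1cccc(NC(=O)N[C@H](C)c2ccccc2)c1`, compound 2 `CC(=O)c1cccc(NC(=O)N[C@H](C)c2ccccc2)c1` and compound 3 `C[C@@H](NC(=O)Nc1cccc(F)c1)c1ccccc1` share one core and differ only in one group on an aromatic carbon. In an ADME assay on the whole organism with Oryza sativa as the target, tested at 0.1 uM (a higher number here means a weaker effect of the compound at the concentration tested, a lower number a stronger effect), compound 1 gives 74%, compound 2 gives 98% and compound 3 gives 99%. Compound 3 and compound 2 sit within the scatter of each other, while compound 1 lies clearly lower, as the steps of a number 25 percentage points higher from compound 1 to compound 3 (beyond the scatter) and a number 24 percentage points higher from compound 1 to compound 2 (beyond the scatter) show.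

Compound 4 `C[C@@H](NC(=O)Nc1cccc(I)c1)c1ccccc1` arises from compound 3 through the change (iodo in place of fluoro on an aromatic carbon). For the measured compounds named here, no measured step exchanges one halogen for another. The step that bears most closely on it, a number 1 percentage points higher from compound 2 to compound 3 (within the scatter), is within the scatter, and compound 3 already stands close to the top of the scale, so there is little room for a further rise. Compound 4 is therefore expected to show no step beyond the scatter, a number 6 percentage points lower from compound 3 to compound 4 (within the scatter), with a small drop more likely than a rise. The estimate for compound 4 in this assay is 93%, with a range from 75% to 100%.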

Compound 4, a percentage reported as activity, at one concentration (the size of the read-out at that concentration, not a potency): 81%
For compound 4 the middle estimate is 12 percentage points above the measured one; measured number inside the range.
By their numbers in this assay, from the lowest: compounds 1 and 4 (each within the scatter of the next); then compounds 2 and 3 (each within the scatter of the next).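

In this assay, for the compounds shown here, the choice of halogen on this aromatic carbon, meta to a large group, turns out to matter: iodo in place of fluoro gives a number 18 percentage points lower from compound 3 to compound 4 (beyond the scatter) and is the first exchange of one halogen for another in this set, while iodo in place of acetyl gives a number 17 percentage points lower from compound 2 to compound 4 (beyond the scatter) in the same direction. Isopropyl is therefore no longer the only group here linked to a lower number, and a number 7 percentage points higher from compound 1 to compound 4 (within the scatter) leaves iodo and isopropyl indistinguishable. Nothing available explains why iodo and isopropyl group together, apart from fluoro and acetyl.

As far as these compounds go, whether chloro or bromo would fall with fluoro or with iodo remains open. So does whether an amine or a carboxylic acid at this place would give a number lower than either iodo or isopropyl.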